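Swapping one aryl group at the cytotoxicity limit

The source may report more compounds than this note shows. Statements on the series, on what has been measured and on what is new or still open speak of the compounds shown alone.

compound 1 `CC(C)N(Cc1cccc(OCCCCCC(=O)O)c1)C(=O)c1ccc(-c2cccc3ccccc23)cc1`: > 26000 nM
compound 2 `CC(C)Oc1cccc(-c2ccc(C(=O)N(Cc3cccc(OCCCCCC(=O)O)c3)C(C)C)cc2)c1`: > 26000 nM
compound 3 `COc1ccc(F)c(-c2ccc(C(=O)N(Cc3cccc(OCCCCCC(=O)O)c3)C(C)C)cc2)c1`: > 26000 nM

All three values come from an ADME assay on HEK293 cells (Homo sapiens) for cytotoxicity, read by CellTiter-Glo and resazurin assay, with a stated time of 72 h (on this read-out higher numbers stand for an effect only at larger amounts of compound and lower numbers for an effect already at smaller amounts), and each is a limit of the assay, not a number. The whole set sits at one point: the limit of > 26000 nM in this assay, at which 3 of the 3 values shown sit. Compound 3 therefore has no exact position, only its limit of > 26000 nM.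

Compound 4 `CC(C)N(Cc1cccc(OCCCCCC(=O)O)c1)C(=O)c1ccc(-c2cccc(Br)c2)cc1` is reached by a single exchange: 3-bromophenyl in place of 2-fluoro-5-methoxyphenyl on an aromatic carbon. Here 3-bromophenyl takes the place of 2-fluoro-5-methoxyphenyl on an aromatic carbon, para to a large group.

Three measured steps exchange a group on an aromatic carbon in the same way. Among the measured compounds shown here, the first is a step that the two limits leave unreadable from compound 1 to compound 2. The second is a step that the two limits leave unreadable from compound 1 to compound 3. The third is a step that the two limits leave unreadable from compound 2 to compound 3. None of them has a readable size, and none gives a direction. They do show that naphthalen-1-yl, 3-isopropoxyphenyl and 2-fluoro-5-methoxyphenyl all leave the read-out at the same limit.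

No step beyond the usual scatter is therefore expected in this assay, and a further limit is the likeliest report. The expected change is a step that the limit leaves unreadable from compound 3 to compound 4. For compound 4 the estimate is 30000 nM, with an expected range from 14000 nM to 60000 nM.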

Compound 4, half-maximal effective concentration: > 26000 nM
Compound 4: no number, only a limit; the forecaster's own chance of this, stated with the estimate: 85%; the middle value is on the limit's open side.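

The steps among compound 1, compound 2, compound 3 and compound 4 cannot be read, since each value is a limit of the assay and not a number: the limit of > 26000 nM in this assay, at which 4 of the 4 values shown sit.

These four compounds leave open how their aryl groups rank in this assay, and at what concentration, if any, each would reach its half-maximal effect.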